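Geometry of a Double Bond and Enzyme Inhibition

The source may hold more compounds than are shown below. What is called first, only, known or untested is meant among the compounds shown, and "the series" means these compounds.

Three quinazoline-type compounds were measured in an assay for inhibition of Dihydrofolate reductase (Homo sapiens); a lower number here means a less potent compound, a higher number a more potent compound, by a factor of ten per unit of this negative logarithm. Compound 1 `Nc1nc(S)c2cc(S(=O)(=O)c3ccc4ccccc4c3)ccc2n1` gives 7.6. Compound 2 `Nc1nc(N)c2cc(Cl)ccc2n1` gives 5.4. Compound 3 `Nc1nc(N)c2c(/C=C\c3ccc4ccccc4c3)cccc2n1` gives 6.52, which places compound 3 second highest of the three: compound 1 sits higher and compound 2 sits lower, both differences lying beyond the usual scatter.

The next compound, compound 4 `Nc1nc(N)c2c(/C=C/c3ccc4ccccc4c3)cccc2n1`, is the same molecule as compound 3 with one alteration: the two compounds have the same atoms and bonds and differ only in configuration as drawn: 1 of 1 stereo elements differ; a double bond is drawn Z in compound 3 and E in compound 4. Going by the values given here, no measured pair so far shows what such a change does, so nothing in the numbers points in either direction. The step from compound 3 to compound 4 in this assay is therefore expected to stay within the scatter, with a number 0.08 log units higher from compound 3 to compound 4 (within the scatter). Compound 4 is estimated at 6.6, ranging from 5.9 to 7.3.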

Compound 4, logarithm of the reciprocal of the active concentration, log(1/C): 5.28
Beside the measured number, compound 4's estimate is 1.32 log units above it; measured number below the stated range.
By their numbers in this assay, from the lowest: compounds 4 and 2 (each within the scatter of the next); then compound 3; then compound 1.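

Changing only the drawn configuration of the double bond from Z to E gives a number 1.24 log units lower from compound 3 to compound 4 (beyond the scatter) in this assay. Going by these compounds alone, no earlier compound showed that, at this position, the arrangement around the double bond can matter even with the same atoms and bonds. The change in number can be assigned to configuration alone because no other structural difference separates the pair: the fact that compounds 3 and 4 differ only in the configuration as drawn

Still open, on these data alone, is how an amide or a saturated chain in place of the double bond would compare with compound 3. The compounds shown also do not tell whether the same Z to E change would matter elsewhere on the shared core.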